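Bromo in Place of Chloro on the Benzyl Group

The source may report more compounds than this note shows. Statements on the series, on what has been measured and on what is new or still open speak of the compounds shown alone.

Three measured compounds share one core. Compound 1 `O[C@@H]1[C@H](O)CS[C@H]1Cn1cnc2c(NCc3cccc(Br)c3)nc(Cl)nc21` gives 23.6% in an assay on CHO cells for displacement of a labelled ligand from adenosine receptor A1 (Homo sapiens), with a stated time of 60 min, tested at 10 uM; a lower number here means less inhibition, a higher number more inhibition at the concentration tested (going by the name of the read-out). Compound 2 `O[C@@H]1[C@H](O)CS[C@H]1Cn1cnc2c(NCc3cccc(Cl)c3)ncnc21` gives 3.3% in this assay, and compound 3 `O[C@@H]1[C@H](O)CS[C@H]1Cn1cnc2c(NCc3cccc(Cl)c3)nc(Cl)nc21` gives 3.2%. Compound 2 thus stands second of the three: its number and that of compound 3 lie within the scatter of each other, while the number of compound 1 lies beyond the scatter above it. Compound 4 `O[C@@H]1[C@H](O)CS[C@H]1Cn1cnc2c(NCc3cccc(Br)c3)ncnc21` differs from compound 2 by bromo in place of chloro on an aromatic carbon. Within the data shown here, two measured steps bear on this change. The step of a number 20.4 percentage points lower from compound 1 to compound 3 (beyond the scatter) is the same exchange run in the opposite direction, and it was the only change beyond the scatter seen among these compounds. The step of a number 0.1 percentage points lower from compound 2 to compound 3 (within the scatter) shows that chloro in place of hydrogen on an aromatic carbon made no difference beyond the scatter, so the reading of compound 1 carries over to the core of compound 2. The bromo is therefore expected to raise the number. Compound 4 is expected to show a number 19.7 percentage points higher from compound 2 to compound 4 (beyond the scatter) and to reach about 23%, with a range from 8% to 38%.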

Compound 4, a percentage reported as inhibition, at one concentration (the size of the read-out at that concentration, not a potency): 6.6%
For compound 4 the middle estimate is 16.4 percentage points above the measured one; measured number below the stated range.
By their numbers in this assay, from the lowest: compounds 3, 2 and 4 (each within the scatter of the next); then compound 1.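

Bromo in place of chloro on the benzyl group gives a number 3.3 percentage points higher from compound 2 to compound 4 (within the scatter), so 3-bromobenzyl alone does not bring the number seen for compound 1. The chloro on the core made no difference beyond the scatter alongside 3-chlorobenzyl, but alongside 3-bromobenzyl, hydrogen in its place gives a number 17 percentage points lower from compound 1 to compound 4 (beyond the scatter). The two changes therefore do not add up independently in this assay: the same change on two cores in this assay, a number 20.4 percentage points lower (beyond the scatter) from compound 1 to compound 3 and a number 3.3 percentage points lower (within the scatter) from compound 4 to compound 2, 17.1 percentage points apart, beyond the scatter of two such steps

Among these compounds, this dependence rests on compound 1 alone, the only compound with a number beyond the scatter of the others, and these readings at one concentration give no potency. As far as these compounds go, whether it extends to other groups on the benzyl ring, such as iodo or methoxy, or to an amine in place of the chloro on the core, remains open.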